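Methylsulfonyl for Oxanyl on a Chemokine Receptor Antagonist Core

A few compounds are considered here, and "the series" means these few. Any claim that something is new, unique, unknown or untested is made for them only; others in the source may bear on it.

Measured so far:
compound 1, `Cc1nc(C)n(CC(=O)N2CCN(c3sc(C(F)(F)F)nc3-c3nc4ccc(C5CCOCC5)cc4[nH]3)C[C@H]2C)n1`: 3.3 nM
compound 2, `Cc1nc(C)n(CC(=O)N2CCN(c3sc(C(F)(F)F)nc3-c3nc4cccc(C)c4[nH]3)C[C@H]2C)n1`: 3.1 nM
compound 3, `Cc1nc(C)n(CC(=O)N2CCN(c3sc(C(F)(F)F)nc3-c3nc4c(C(F)(F)F)cccc4[nH]3)C[C@H]2C)n1`: 6 nM

Of the compounds shown here, three on one shared core have been tested in a functional assay on CHO-K1 cells for antagonist activity at C-X-C chemokine receptor type 3 (Homo sapiens), read by FLIPR, with a stated time of 10 min, in the presence of a further agent that is not named here; on this read-out higher numbers stand for weaker inhibition and lower numbers for stronger inhibition. Compound 1 gives 3.3 nM, the second highest of the three numbers; compound 2 sits nearest with 3.1 nM, and compound 3 furthest with 6 nM, both gaps within the usual scatter, so none of the three can be called more or less potent than another.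

Compound 4, `Cc1nc(C)n(CC(=O)N2CCN(c3sc(C(F)(F)F)nc3-c3nc4ccc(S(C)(=O)=O)cc4[nH]3)C[C@H]2C)n1`, has not yet been measured. It differs from compound 1 in one place: methylsulfonyl in place of oxan-4-yl on an aromatic carbon. Going by the values given here, no step between two measured compounds that differ in a single place is available to guide this change. The measured numbers span only a narrow band, and the step of a 1.8-fold higher number from compound 1 to compound 4 (0.26 log units; within the scatter) is expected to be small, leaning toward a higher number without clearly leaving the scatter. Compound 4 is estimated at 6 nM, within a likely range from 2 nM to 20 nM.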

Compound 4, half-maximal inhibitory concentration: 10 nM
The estimate for compound 4 lay 1.7-fold (0.22 log units) below the measured number; the measured number falls inside the stated range.
By their numbers in this assay, from the lowest: compounds 2, 1, 3 and 4 (each within the scatter of the next, the first and the last beyond it).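

Going by these compounds alone, replacing oxan-4-yl with methylsulfonyl on this aromatic carbon gives the first single-place step on the shared core in this assay, a 3.0-fold higher number from compound 1 to compound 4 (0.48 log units; beyond the scatter). This shows that the number responds to the group at this position, though only modestly, and that the higher number comes with a group that has no ring. No measurement shown gives a reason for this step. Still open, going by these compounds, is whether the shift follows from losing the ring or from methylsulfonyl itself, and how an amine or a carboxylic acid on this carbon would read.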